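This account rests on a few compounds, and the source may have more. Where it says the series, first, only, none or still open, it means among the compounds named here.

Measured compounds:
- compound 1, `CN(C)CCn1cnnc1-c1cc(Oc2ccc(NC(=O)N/N=C/c3c(Cl)cccc3Cl)cc2F)ccn1`, in a functional assay on A549 cells (Homo sapiens) for cytotoxicity, read by MTT assay, with a stated time of 72 h (on this read-out higher numbers stand for weaker inhibition and lower numbers for stronger inhibition), gives 1410 nM
- compound 2, `COc1ccc(/C=N/NC(=O)Nc2ccc(Oc3ccnc(-c4nncn4CCN(C)C)c3)c(F)c2)c(OC)c1`, in this assay gives 2820 nM
- compound 3, `COc1ccc(/C=N/NC(=O)Nc2ccc(Oc3ccnc(-c4nncn4CCN(C)C)c3)c(F)c2)c(OC)c1OC`, in this assay gives 6680 nM

Among these three, compound 1 has the lowest number: compound 2 lies close to it, within the usual scatter, while compound 3 stands apart, with the step of a 4.7-fold higher number from compound 1 to compound 3 (0.68 log units; beyond the scatter).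

Compound 4, `CN(C)CCn1cnnc1-c1cc(Oc2ccc(NC(=O)N/N=C/c3ccc(F)cc3)cc2F)ccn1`, is not yet measured. It differs from compound 1 in one place: 4-fluorophenyl in place of 2,6-dichlorophenyl on a carbon with a double bond to nitrogen.

Two measured steps change the same group on the same carbon. The step of a 2.0-fold higher number from compound 1 to compound 2 (0.30 log units; within the scatter) is within the scatter, and the step of a 4.7-fold higher number from compound 1 to compound 3 (0.68 log units; beyond the scatter) is a modest rise. Both replace the 2,6-dichlorophenyl by another six-membered aromatic ring of carbon only, and neither lowers the number. A 4-fluorophenyl is a further such replacement, so a small rise, or no change beyond the scatter, is the most likely outcome for compound 4 in this assay.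

Compound 4 is therefore expected to give about 2500 nM, with a plausible range from 1000 nM to 6500 nM, which corresponds to an expected step of a 1.8-fold higher number from compound 1 to compound 4 (0.25 log units; within the scatter).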

Compound 4, half-maximal inhibitory concentration: 1790 nM
Compound 4: the middle estimate sits 1.4-fold (0.15 log units) above what was measured; low and high end bracket the measured number.
By their numbers in this assay, from the lowest: compounds 1, 4 and 2 (each within the scatter of the next); then compound 3.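

In this assay, replacing the 2,6-dichlorophenyl with 4-fluorophenyl gives a 1.3-fold higher number from compound 1 to compound 4 (0.10 log units; within the scatter) and so stays within the scatter, which shows that both chlorines can be given up for one fluorine on the ring without a measurable shift in this read-out. The same ring gives a 1.6-fold lower number from compound 2 to compound 4 (0.20 log units; within the scatter) against the 2,4-dimethoxyphenyl, also within the scatter, but a 3.7-fold lower number from compound 3 to compound 4 (0.57 log units; beyond the scatter) against the 2,3,4-trimethoxyphenyl, so this position tolerates rings with quite different groups on them, and compound 3 alone stands apart from the other three compounds. Nothing available here explains the gap between compound 3 and the others.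

Going by these compounds, all four compounds carry a six-membered aromatic ring of carbon only at this carbon, so it remains open whether a pyridine ring, with nitrogen in the ring itself, or a saturated cyclohexyl ring would stay in the same range. On these data alone, it is also open whether the plain unsubstituted phenyl ring would match compound 4, or whether a ring bearing an amine or a carboxylic acid would move the number in either direction.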